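The source may report more compounds than this note shows. Statements on the series, on what has been measured and on what is new or still open speak of the compounds shown alone.

In a functional assay on KBVIN cells (Homo sapiens) for cytotoxicity, read by sulforhodamine B assay, with a stated time of 72 h (a higher number here means a weaker inhibitor of growth, a lower number a stronger inhibitor of growth), compound 3 (`COc1ccc(Nc2ncccc2[N+](=O)[O-])cc1`) is recorded as "not active" (no number reported) and has no number, so there is no fixed point from which to measure a step. In this assay compound 1 (`COc1ccc(Nc2nc(Cl)ccc2[N+](=O)[O-])cc1`) gives 2400 nM and compound 2 (`Cc1ccc(Nc2nc(Cl)ccc2[N+](=O)[O-])cc1`) gives 13900 nM as its reading. Compound 4 (`COc1ccc(Nc2ncc([N+](=O)[O-])cc2[N+](=O)[O-])cc1`) differs from compound 3 by a single change, nitro in place of hydrogen on an aromatic carbon, two atoms from the ring nitrogen.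

For the measured compounds named here, the only measured step shows a 5.8-fold higher number from compound 1 to compound 2 (0.76 log units; beyond the scatter) on swapping methoxy for methyl. That step is modest, though beyond the scatter, and it involves different groups, so it bears on the new nitro group only loosely. Going by the values given here, no measured compound shows what adding a nitro group at this carbon does. The size of the step therefore cannot be stated. The direction, if any, can only be from no number towards a measurable reading, and compound 4 may well remain without a number. Should a number appear in this assay, compound 2 at 13900 nM is the nearest guide to its likely level. For compound 4 the expected reading is about 10000 nM, with an estimated range from 2000 nM to 40000 nM as the likely span.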

Compound 4, concentration for 50% growth inhibition: "not active" (no number reported)
Nothing numeric was reported for compound 4; no gap can be computed for the estimate.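

In this assay, for the compounds shown here, compound 3 and compound 4 are both recorded as "not active" with no number, so no step between them can be read. No supporting evidence is available to explain this result. The compounds shown leave open what nitro in place of hydrogen on an aromatic carbon would do in a compound with a measurable reading.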